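This account rests on a few compounds, and the source may have more. Where it says the series, first, only, none or still open, it means among the compounds named here.

Working notes on the series. Compound 1 `COc1ccc(F)cc1CNCCCNc1ccnc2cc(CCc3ccccc3)ccc12` is the reference point. In an ADME assay for permeability, using PAMPA, with a stated time of 30 min, at pH 7.4 (a higher number here means that the compound crosses the layer faster, a lower number that the compound crosses the layer more slowly), compound 1 gives 23 10^-6 cm/s. Compound 2 `c1ccc(CCc2ccc3c(NCCCNCc4ccco4)ccnc3c2)cc1` gives 23 10^-6 cm/s in this assay, and compound 3 `COc1cccc(CNCCCNc2ccnc3cc(-c4ccc(C(C)(C)C)cc4)ccc23)c1O` gives 237 10^-6 cm/s. Compound 1 stands level with compound 2 at the digits shown, the two together the lowest of the three numbers; compound 3 lies far above, a gap beyond the scatter, but compound 3 differs from compound 1 in two places, so no single step can be read from that pair.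

Going by the values given here, the one measured step, no change at the digits printed from compound 1 to compound 2 (within the scatter), exchanges the group on a saturated chain carbon bound to an amine nitrogen and leaves the aromatic carbon untouched.

Compound 4 `COc1ccc(F)cc1CNCCCNc1ccnc2cc(Oc3ccc(Cl)cc3)ccc12` is not yet measured. It carries the change (4-chlorophenoxy in place of phenethyl on an aromatic carbon). Among the compounds with values here, no measured step touches this position, so the only guide is that the one recorded exchange of a side group left the number unchanged. Compound 4 is therefore expected to give about 30 10^-6 cm/s, with a range from 10 10^-6 cm/s to 90 10^-6 cm/s. This estimate means a step of a 1.3-fold higher number from compound 1 to compound 4 (0.12 log units; within the scatter), no change beyond the scatter being expected.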

Compound 4, apparent permeability: 317 10^-6 cm/s
Beside the measured number, compound 4's estimate is 11-fold (1.02 log units) below it, and the stated range ends below it.
By their numbers in this assay, from the lowest: compounds 1 and 2 (each within the scatter of the next); then compounds 3 and 4 (each within the scatter of the next).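

In this assay the exchange of phenethyl for 4-chlorophenoxy on the aromatic carbon gives a 14-fold higher number from compound 1 to compound 4 (1.14 log units; beyond the scatter) and so shows that this position can move the read-out, whereas the exchange on the saturated chain carbon gave no change at the digits printed from compound 1 to compound 2 (within the scatter) in the same assay. The two groups match in heavy-atom count and each holds one six-membered aromatic ring of carbon only, so the step comes without a difference in those counts; the entering group brings an oxygen and a chlorine. Nothing measured on these compounds accounts for the size of the step.

The compounds shown do not separate the part played by the oxygen from that of the chlorine, as an unsubstituted phenoxy or a 4-chlorophenethyl group on this carbon would. Going by these compounds, it also remains open whether a morpholine or a carboxylic acid here would follow the same direction.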